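A few compounds are considered here, and "the series" means these few. Any claim that something is new, unique, unknown or untested is made for them only; others in the source may bear on it.

Compound 1 `C#CCN(c1nc(-c2cccc(C)c2)no1)C1CCCCC1` gives 25.9 ug/mL in an ADME assay on RAW264.7 cells (Mus musculus) for cytotoxicity, read by MTT assay, with a stated time of 48 h; a lower number here means that less compound is tolerated, a higher number that more compound is tolerated.
Compound 2 `CC(=O)OC[C@H]1O[C@H](OC[C@@H](Cn2cc(CN(c3nc(-c4ccc(Cl)cc4)no3)C3CCCCC3)nn2)OC(C)=O)C=C[C@@H]1OC(C)=O` gives 35.5 ug/mL.
Compound 3 `C#CCN(c1nc(-c2ccc(C#C)cc2)no1)C1CCCCC1` gives 13.1 ug/mL.

Among these three numbers compound 2 stands highest, though the gap to compound 1 lies within the usual scatter of the assay, while the gap to compound 3 lies beyond it. Compound 4 `CC(=O)OC[C@H]1O[C@H](OC[C@@H](Cn2cc(CN(c3nc(-c4ccc(Br)cc4)no3)C3CCCCC3)nn2)OC(C)=O)C=C[C@@H]1OC(C)=O` differs from compound 2 in one place, with bromo in place of chloro on an aromatic carbon. Among the measured compounds shown here, no measured pair in this set shows what such a change does here, so there is no step to lean on. With one halogen exchanged for another of the same kind at the same spot, compound 4 is expected to sit close to compound 2, at an estimated 33 ug/mL with a range from 20 ug/mL to 55 ug/mL. The step expected from this is a 1.1-fold lower number from compound 2 to compound 4 (0.03 log units; within the scatter), not beyond the scatter.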

Compound 4, half-maximal cytotoxic concentration: 39.1 ug/mL
Estimate against measurement, compound 4: 1.2-fold (0.07 log units) below; measured number inside the range.
By their numbers in this assay, from the lowest: compounds 3, 1, 2 and 4 (each within the scatter of the next, the first and the last beyond it).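

Among the compounds shown here, this is the first pair in the set that differs in one place, and in this assay it gives a 1.1-fold higher number from compound 2 to compound 4 (0.04 log units; within the scatter) for bromo in place of chloro on an aromatic carbon para to a large group. At this position, then, one halogen can stand in for the other without a step beyond the scatter, though this rests on a single pair. Nothing measured here bears on why the two halogens match.

On these data alone, whether an amine or a carboxylic acid at this position would also stay within the scatter remains open. So does whether the same exchange behaves alike in the compounds without the sugar-bearing side chain.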